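The compounds below may be only part of what the source reports. "The series", "measured", "known", "first", "only" and "open" are said of these compounds alone.

Compound 2 `Cc1ccc(C(=O)NN(C(=O)c2ccccc2Cl)C(C)(C)C)cc1` gives 18.6 nM in an assay on cells for agonist activity at ecdysone receptor (Bombyx mori), read by a luciferase reporter, with a stated time of 24 h (on this read-out higher numbers stand for an effect only at larger amounts of compound and lower numbers for an effect already at smaller amounts), the lower of the two numbers seen so far; compound 1 `CC(C)(C)N(NC(=O)c1cccc(C#N)c1)C(=O)c1ccccc1Cl` gives 955 nM. Among the compounds with values here, the only measured step, a 51-fold lower number from compound 1 to compound 2 (1.71 log units; beyond the scatter), exchanged one whole aromatic group for another and so bears only loosely on the next change. Compound 3 `Cc1ccc(C(=O)NN(C(=O)c2ccccc2Cl)C(C)(C)C)c(C)c1` differs from compound 2 by methyl in place of hydrogen on an aromatic carbon. Within the data shown here, with no step of this kind measured, compound 3 is expected to show a step of a 1.3-fold higher number from compound 2 to compound 3 (0.13 log units; within the scatter), small and likely within the scatter. Compound 3 is therefore estimated at 25 nM, with a range from 8 nM to 80 nM.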

Compound 3, half-maximal effective concentration: 162 nM
Compound 3: middle estimate off by 6.5-fold (0.81 log units), on the low side; the measured number lies above the stated range.
By their numbers in this assay, from the lowest: compound 2; then compound 3; then compound 1.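

Adding one methyl on this aromatic carbon, ortho to a large group, is far from a neutral change: it brings an 8.7-fold higher number from compound 2 to compound 3 (0.94 log units; beyond the scatter). The 2,4-dimethylphenyl group still holds a clear advantage over 3-cyanophenyl, with a 5.9-fold lower number from compound 1 to compound 3 (0.77 log units; beyond the scatter). No measurement at hand says why the added methyl matters so much. Still open, on these data alone, is whether a fluorine atom or a methoxy group at this same place would give a similar rise in the number. Also open, as far as these compounds go, is whether the methyl would have the same effect without the other methyl group on the ring.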